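From 3-bromophenyl to 4-methoxyphenyl on a shared core

The source may hold more compounds than are shown below. What is called first, only, known or untested is meant among the compounds shown, and "the series" means these compounds.

Values so far in a functional assay on MDA-MB-436 cells (Homo sapiens) for antiproliferative activity, read by MTT assay, with a stated time of 24 h (on this read-out higher numbers stand for weaker inhibition and lower numbers for stronger inhibition), for two compounds:
- Compound 1 `O=C(O)CC(NC(=O)c1ccc(F)cc1)c1ccc(Cl)cc1Cl` gives 55800 nM
- Compound 2 `O=C(O)CC(NC(=O)c1cccc(Br)c1)c1ccc(Cl)cc1Cl` gives > 100000 nM (a limit)

Compound 2 has no exact number here, because its > 100000 nM is a limit of the assay and not a measured value. The next compound, compound 3 `COc1ccc(C(=O)NC(CC(=O)O)c2ccc(Cl)cc2Cl)cc1`, keeps the shared core and changes one group, with 4-methoxyphenyl in place of 3-bromophenyl on a carbonyl carbon.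

Within the data shown here, only one measured step bears on this change: an at least 1.7-fold higher number from compound 1 to compound 2 (0.25 log units; that floor lies within the scatter). Its floor lies within the scatter, so it gives no firm sign that swapping the group on the carbonyl carbon moves the read-out. Among the measured compounds shown here, the only true number available is the one for compound 1 at 55800 nM, so that value serves as the anchor, and no large change is expected. The expected step is small, not clearly beyond the scatter, and if anything towards a lower number: an at least 1.3-fold lower number from compound 2 to compound 3 (0.12 log units; that floor lies within the scatter). For compound 3 the estimated value is 75000 nM, with an expected range from 35000 nM to 130000 nM.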

Compound 3, half-maximal inhibitory concentration: > 100000 nM
Compound 3 was reported as a limit; the forecaster's own chance of this, stated with the estimate: 40%; middle value at least 1.3-fold (0.12 log units) from the limit.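

In this assay compound 3 gives > 100000 nM, which is a limit of the assay and not a number. With a limit on each side, the step between compound 2 and compound 3 cannot be read, so the two groups cannot be ranked against each other. Methoxy in place of fluoro on an aromatic carbon gives an at least 1.7-fold higher number from compound 1 to compound 3 (0.25 log units; that floor lies within the scatter), so this swap, like the earlier one to 3-bromophenyl, shows no firm change, but a second, different group on the carbonyl carbon now ends at the same ceiling, leaving compound 1 as the only exact value in the set: the limit of > 100000 nM in this assay, at which 2 of the 3 values shown sit.

The compounds shown leave open how far compound 2 and compound 3 really lie from compound 1, and whether either differs from it by more than the usual scatter of repeated measurements. On these data alone, compound 1 gives 55800 nM, and also open is whether an amine or a carboxylic acid on that aromatic carbon, in place of methoxy, would give a clearly lower number.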